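Trimethoxyphenyl on the enamine nitrogen of compound 2

The compounds below may be only part of what the source reports. "The series", "measured", "known", "first", "only" and "open" are said of these compounds alone.

Of the compounds shown here, two built on the same enaminone core have been tested so far. Compound 1 `COc1cc(N/C=C\C(=O)c2cn(-c3ccccc3)nc2-c2ccccc2)cc(OC)c1OC` carries a trimethoxyphenyl on the amine nitrogen and a plain phenyl on the pyrazole; in a functional assay on U-87MG ATCC cells (Homo sapiens) for antiproliferative activity, read by MTT assay, with a stated time of 48 h (on this read-out lower numbers stand for stronger inhibition and higher numbers for weaker inhibition), compound 1 gives 2350 nM. Compound 2 `COc1cc(-c2nn(-c3ccccc3)cc2C(=O)/C=C\Nc2ccc(Cl)cc2)cc(OC)c1OC` swaps these roles, with a 4-chlorophenyl on the amine nitrogen and the trimethoxyphenyl on the pyrazole; in this assay compound 2 gives 3210 nM. Compound 2 has the larger of the two figures, but its gap to compound 1 lies within the usual scatter of this assay, so the two cannot be told apart on potency.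

Compound 3 `COc1cc(N/C=C\C(=O)c2cn(-c3ccccc3)nc2-c2cc(OC)c(OC)c(OC)c2)cc(OC)c1OC` keeps everything from compound 2 except one change: 3,4,5-trimethoxyphenyl in place of 4-chlorophenyl on an amine nitrogen. The result is a molecule bearing trimethoxyphenyl groups at both positions. Within the data shown here, no measured pair shows this exact change, so the expected step from compound 2 to compound 3 is estimated as small, at most a modest move toward stronger inhibition, given that compound 1 with a trimethoxyphenyl on that nitrogen gave 2350 nM; the estimated step is a 1.6-fold lower number from compound 2 to compound 3 (0.21 log units; within the scatter). Compound 3 is therefore expected to give about 2000 nM, within a range of 600 nM to 6500 nM.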

Compound 3, half-maximal inhibitory concentration: 5100 nM
Compound 3: the middle estimate sits 2.6-fold (0.41 log units) below what was measured; low and high end bracket the measured number.
By their numbers in this assay, from the lowest: compounds 1, 2 and 3 (each within the scatter of the next, the first and the last beyond it).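

In this assay, 3,4,5-trimethoxyphenyl in place of 4-chlorophenyl on the amine nitrogen gives a 1.6-fold higher number from compound 2 to compound 3 (0.20 log units; within the scatter), so on this nitrogen a group with 12 heavy atoms and 3 hydrogen-bond acceptors cannot be told apart from one with 7 heavy atoms and 0 acceptors. Among these compounds, the other single change, 3,4,5-trimethoxyphenyl in place of phenyl on an aromatic carbon, gives a 2.2-fold higher number from compound 1 to compound 3 (0.34 log units; beyond the scatter), which is modest but is the first step here to clear the usual scatter, so with a trimethoxyphenyl on the nitrogen, this second place shows a real, if small, weakening of inhibition. Nothing available here accounts for either step.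

On these data alone, these readings rest on one pair each, so it remains open whether a much smaller group on the amine nitrogen, such as methyl, or a ring holding nitrogen, such as pyridyl, would move the number beyond the scatter. As far as these compounds go, it is equally open whether the weakening on the aromatic carbon needs all three methoxy groups, which a single 4-methoxyphenyl at that place could test.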